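The source may hold more compounds than are shown below. What is called first, only, known or untested is meant among the compounds shown, and "the series" means these compounds.

Among the measured compounds shown here, in a functional assay on the whole organism (strain Wistar) for inhibition, with Rattus norvegicus as the target, with a stated time of 5 days, at a dose of 50 mg/kg by the oral route (a lower number here means less inhibition, a higher number more inhibition at the dose given (going by the name of the read-out)), compound 2 `CC(=O)CCc1ccc2ccccc2c1` gives 20%, the highest of the two numbers so far. For the measured compounds named here, compound 1 `CCOc1ccc2cc(CCC(C)=O)ccc2c1` gives 12% in this assay, and the step of a number 8 percentage points higher from compound 1 to compound 2 (within the scatter) is the only comparison at hand: hydrogen in place of ethoxy on an aromatic carbon, within the scatter. Compound 3 `CC(=O)CCc1ccc2cc(Cl)ccc2c1` differs from compound 2 by chloro in place of hydrogen on an aromatic carbon. Going by the values given here, no measured step shows a chloro entering, and the one step on this core stayed within the scatter, so for compound 3 the expected step is a number 5 percentage points higher from compound 2 to compound 3 (within the scatter), with no change beyond the scatter foreseen. Compound 3 is therefore estimated at 25%, between 10% and 40%.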

Compound 3, a percentage reported as inhibition, in the whole organism at one dose (the size of the read-out at that dose, not a potency): 53%
Beside the measured number, compound 3's estimate is 28 percentage points below it, outside the stated range (above it).
By their numbers in this assay, from the lowest: compounds 1 and 2 (each within the scatter of the next); then compound 3.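

In this assay, among the compounds shown here, the group at this position on the shared core can change the read-out: chloro in place of hydrogen gives a rise (a number 33 percentage points higher from compound 2 to compound 3 (beyond the scatter)) that is the first step beyond the scatter. Chloro also separates from ethoxy at this position (a number 41 percentage points higher from compound 1 to compound 3 (beyond the scatter)), whereas hydrogen and ethoxy stayed within the scatter of each other. No measured evidence available here explains this rise.

As far as these compounds go, it remains open whether the rise is specific to chloro or extends to bromo or methyl at this position. Also open, from the compounds shown here alone, is whether a carboxylic acid in place of the ketone carbonyl would keep the level of compound 3.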